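Compound 3 to compound 4: a step among limits

This account rests on a few compounds, and the source may have more. Where it says the series, first, only, none or still open, it means among the compounds named here.

- compound 1 `OC[C@H]1O[C@@H](n2cnc3c(COc4ccccc4)ncnc32)[C@H](O)[C@@H]1O` gives > 100000 nM as a limit
- compound 2 `[N-]=[N+]=NCc1ncnc2c1ncn2[C@@H]1O[C@H](CO)[C@@H](O)[C@H]1O` gives > 250000 nM as a limit
- compound 3 `OC[C@H]1O[C@@H](n2cnc3c(Cn4ccc5ccccc54)ncnc32)[C@H](O)[C@@H]1O` gives > 250000 nM as a limit

All three results come from a functional assay on Huh-7 cells (Homo sapiens) for cytotoxicity, read by MTT assay, with a stated time of 3 days (a lower number here means that less compound is tolerated, a higher number that more compound is tolerated), and none is an exact number. Compound 3 has only its limit of > 250000 nM to show, not a measured value. Compound 4 `O=C1CCCN1Cc1ncnc2c1ncn2[C@@H]1O[C@H](CO)[C@@H](O)[C@H]1O` carries 2-oxopyrrolidin-1-yl in place of 1H-indol-1-yl on a saturated chain carbon bound to an aromatic carbon, a change counted as 2-oxopyrrolidin-1-yl in place of 1H-indol-1-yl on a saturated chain carbon bound to an aromatic carbon in full. The measured steps at this place are a step that the two limits leave unreadable from compound 1 to compound 2 and a step that the two limits leave unreadable from compound 1 to compound 3 and a step that the two limits leave unreadable from compound 2 to compound 3 and so none offers a size to carry over. With the limit of > 250000 nM in this assay, at which 2 of the 3 values shown sit, as the reference, the expected change is a number no higher from compound 3 to compound 4 (the limit leaves the size open) and no step beyond the scatter is expected in either direction. Compound 4 is estimated at 250000 nM with an expected range from 100000 nM to 500000 nM and will most likely also be reported as a limit.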

Compound 4, half-maximal cytotoxic concentration: 45000 nM
Beside the measured number, compound 4's estimate is 5.6-fold (0.74 log units) above it; the measured number lies below the stated range.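

With an at least 5.5-fold lower number from compound 3 to compound 4 (0.74 log units; beyond the scatter) and an at least 5.5-fold lower number from compound 2 to compound 4 (0.74 log units; beyond the scatter) and an at least 2.2-fold lower number from compound 1 to compound 4 (0.34 log units; beyond the scatter) in this assay the group on a saturated chain carbon bound to an aromatic carbon proves able to change how much compound the cells tolerate. Among the compounds shown, only 2-oxopyrrolidin-1-yl in compound 4 brings the value down to an exact number. These sizes are minimums because the other values are limits of the assay: the limit of > 250000 nM in this assay, at which 2 of the 4 values shown sit. On these data alone, what in this group carries the step stays open. Pyrrolidin-1-yl, the same ring without the carbonyl, would test whether the carbonyl matters.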